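Swapping pyridin-3-yl for 4-(trifluoromethyl)benzyl on the shared core

This account rests on a few compounds, and the source may have more. Where it says the series, first, only, none or still open, it means among the compounds named here.

In a functional assay on SGC-7901 cells (Homo sapiens) for inhibition, read by MTT assay, with a stated time of 72 h (on this read-out higher numbers stand for weaker inhibition of growth and lower numbers for stronger inhibition of growth), compound 1 `O[C@H](COCCOC[C@@H](O)Cc1cn(Cc2ccc(Oc3ccccc3)cc2)nn1)Cc1ccc(-c2ccccc2)cc1` gives 4500 nM and compound 2 `O[C@H](COCCOC[C@@H](O)Cc1cn(Cc2cccc(-c3ccccc3)c2)nn1)Cc1ccc(-c2ccccc2)cc1` gives 10600 nM while compound 3 `O[C@H](COCCOC[C@@H](O)Cc1cn(-c2cccnc2)nn1)Cc1ccc(-c2ccccc2)cc1` gives 29800 nM as the highest number of the three. Compound 3 therefore shows the weakest inhibition of growth in this small set, and its gap to each of the others lies beyond the usual scatter.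

Compound 4 `O[C@H](COCCOC[C@@H](O)Cc1cn(Cc2ccc(C(F)(F)F)cc2)nn1)Cc1ccc(-c2ccccc2)cc1` differs from compound 3 in one group: 4-(trifluoromethyl)benzyl in place of pyridin-3-yl on an aromatic nitrogen and in words this puts 4-(trifluoromethyl)benzyl in place of pyridin-3-yl on an aromatic nitrogen. Among the compounds with values here, no measured pair of compounds differs in just one place, so no direct precedent exists for this swap. Within the data shown here, the only guide is indirect. Compound 1 at 4500 nM and compound 2 at 10600 nM also carry a substituted benzyl group on that nitrogen, and both numbers lie below that of compound 3. Their groups differ from the incoming one, however, and three compounds are thin evidence.

a 3.0-fold lower number from compound 3 to compound 4 (0.47 log units; beyond the scatter) is therefore expected to be a moderate drop in this assay toward stronger inhibition of growth, probably just beyond the scatter. For compound 4 the estimated value is 10000 nM with 4000 nM to 24000 nM as its expected range.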

Compound 4, concentration for 50% growth inhibition: 8700 nM
Beside the measured number, compound 4's estimate is 1.1-fold (0.06 log units) above it, within the range that was stated.
By their numbers in this assay, from the lowest: compounds 1, 4 and 2 (each within the scatter of the next, the first and the last beyond it); then compound 3.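

Placing 4-(trifluoromethyl)benzyl in place of pyridin-3-yl on the aromatic nitrogen gives a 3.4-fold lower number from compound 3 to compound 4 (0.53 log units; beyond the scatter) in this assay, the first change at this position measured in one place only, and it moves the read-out toward stronger inhibition of growth. The two other single-place comparisons show that the outer part of the benzyl group can vary considerably without a readable effect: 4-(trifluoromethyl)phenyl in place of 3-phenylphenyl on the saturated chain carbon gives a 1.2-fold lower number from compound 2 to compound 4 (0.09 log units; within the scatter), and trifluoromethyl in place of phenoxy on an aromatic carbon gives a 1.9-fold higher number from compound 1 to compound 4 (0.29 log units; within the scatter), so compound 4 cannot be ranked against either compound 1 or compound 2. No accompanying measurement speaks to the reason for any of these steps.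

On these data alone, the step from compound 3 to compound 4 changes both the ring and the saturated chain carbon that joins it to the nitrogen, so the contribution of each stays open, and plain benzyl or pyridin-3-ylmethyl on that nitrogen would separate the two. Also open, as far as these compounds go, is how the read-out would respond to an amine or a carboxylic acid on the benzyl ring in place of trifluoromethyl.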